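The source may hold more compounds than are shown below. What is called first, only, known or untested is meant among the compounds shown, and "the series" means these compounds.

Working notes on the series. The shared core is carried by compound 1 `Cc1c2c(n3c1CCCNC[C@H](C)Nc1cc-3ccc1C(N)=O)CC(C)(C)CC2=O`, compound 2 `Cc1c2c(n3c1CCNC[C@@H](C)[C@H](C)Nc1cc-3ccc1C(N)=O)CC(C)(C)CC2=O`, compound 3 `Cc1c2c(n3c1CCN(C)C[C@@H](C)[C@H](C)Nc1cc-3ccc1C(N)=O)CC(C)(C)CC2=O` and the unmeasured compound 4 `Cc1c2c(n3c1CCN(C(=O)C1(N)CCCC1)C[C@@H](C)[C@H](C)Nc1cc-3ccc1C(N)=O)CC(C)(C)CC2=O`. In a functional assay on HCT-116 cells (Homo sapiens) for antiproliferative activity (on this read-out lower numbers stand for stronger inhibition and higher numbers for weaker inhibition), compound 1 gives 93 nM, compound 2 gives 24 nM and compound 3 gives 27 nM; compound 2 thus holds the lowest number of the three, with compound 3 nearest and compound 1 furthest. Compound 4 differs from compound 2 by a group of 8 heavy atoms (6 carbon, 1 nitrogen, 1 oxygen; one five-membered non-aromatic ring of carbon only) in place of a hydrogen atom, on an amine nitrogen in a ring. For the measured compounds named here, the only measured step touching that nitrogen is a 1.1-fold higher number from compound 2 to compound 3 (0.05 log units; within the scatter), so substitution there has so far cost nothing beyond the scatter; the entering group is, however, far larger than methyl, carrying one five-membered non-aromatic ring of carbon only and 1 hydrogen-bond donor with 2 hydrogen-bond acceptors. A step of about a 1.7-fold higher number from compound 2 to compound 4 (0.22 log units; within the scatter) is therefore expected, with wide uncertainty. Compound 4 is estimated at 40 nM in this assay, range 12 nM to 130 nM.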

Compound 4, half-maximal inhibitory concentration: 27 nM
The estimate for compound 4 lay 1.5-fold (0.17 log units) above the measured number, and the stated range covers the measured number.
By their numbers in this assay, from the lowest: compounds 2, 3 and 4 (each within the scatter of the next); then compound 1.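

In this assay, the amine nitrogen in a ring accepts a group of 8 heavy atoms, with its five-membered non-aromatic ring of carbon only, with a 1.1-fold higher number from compound 2 to compound 4 (0.05 log units; within the scatter) and no change at the digits printed from compound 3 to compound 4 (within the scatter). Substitution at this nitrogen therefore stays within the scatter for a group far larger than methyl, not only for methyl itself. Nothing at hand bears on the reason for this result.

Still open, on these data alone, is how an acetyl group on this nitrogen would read. As far as these compounds go, it is also open whether the entering group's amine matters, which a hydroxyl group in its place would test.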